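Phenyl for 1,3-thiazol-2-yl on the saturated ring carbon

A few compounds are considered here, and "the series" means these few. Any claim that something is new, unique, unknown or untested is made for them only; others in the source may bear on it.

Measured so far:
Compound 1 `O=C(NCN1CCC(c2cccc[n+]2[O-])CC1)c1ccccc1`: 63%
Compound 2 `Cc1cccc(NC(=O)CN2CCC(c3nccs3)CC2)c1`: 62%
Compound 3 `O=C(CN1CCC(c2cccc[n+]2[O-])CC1)Nc1ccc(F)cc1F`: 74%

In a functional assay on HEK293 cells for agonist activity at D(4) dopamine receptor (Homo sapiens), read by FLIPR (a higher number here means a larger maximal response, a lower number a smaller maximal response), compound 2 stands lowest of the three numbers. The nearest is compound 1, which lies within the usual scatter of compound 2; the furthest is compound 3, which lies beyond the scatter above compound 2. Compounds 1 and 3 differ from compound 2 in more than one place, so none of these pairs gives a clean step for a single change.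

Compound 4 `Cc1cccc(NC(=O)CN2CCC(c3ccccc3)CC2)c1` differs from compound 2 in one place: phenyl in place of 1,3-thiazol-2-yl on a saturated ring carbon. For the measured compounds named here, no measured pair shows what this change does. Both groups that have been measured on that saturated ring carbon so far sit in a narrow band in this assay, and nothing among the three numbers points to a large move in either direction. The step from compound 2 to compound 4 is therefore expected to stay within the scatter, a number 3 percentage points higher from compound 2 to compound 4 (within the scatter). Compound 4 is estimated to give 65% in this assay, with a range from 50% to 80%.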

Compound 4, largest response reached (reported as efficacy), in percent of the reference or control that the assay uses: 37%
Compound 4: the middle estimate sits 28 percentage points above what was measured, outside the stated range (below it).
By their numbers in this assay, from the lowest: compound 4; then compounds 2 and 1 (each within the scatter of the next); then compound 3.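

In this assay phenyl in place of 1,3-thiazol-2-yl on the saturated ring carbon gives a number 25 percentage points lower from compound 2 to compound 4 (beyond the scatter), so the maximal response at this position depends on which aromatic ring is attached. For the compounds shown here, this is the only single-change reading so far, and it shows that the narrow band among the earlier compounds does not hold for every aromatic group here. No measurement at hand accounts for the step.

As far as these compounds go, whether the ring nitrogen, the sulfur or the ring size governs the step stays open; a pyridine ring or a 1,3-oxazol-2-yl group on the same carbon would help separate these. From the compounds shown here alone, it also remains open whether the step carries over to other amide groups, such as a 2,4-difluorophenyl amide.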